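Pyridin-4-yl Replaces the Piperidinyl Ring on the Piperazine Nitrogen

The source may report more compounds than this note shows. Statements on the series, on what has been measured and on what is new or still open speak of the compounds shown alone.

Compound 1 `Cc1cccc2sc(NC(=O)CCN3CCN(C4CCCCC4)CC3)nc12` and compound 2 `Cc1cccc2sc(NC(=O)CCN3CCN(C4CCN(C)CC4)CC3)nc12` share a common core and are separated by a single change on the ring nitrogen of the piperazine. In an assay on membranes from brain for displacement of a labelled ligand from Sigma non-opioid intracellular receptor 1 (Cavia porcellus), read by scintillation counting, with a stated time of 120 min (on this read-out lower numbers stand for stronger inhibition and higher numbers for weaker inhibition), compound 1 gives 24 nM, whereas compound 2 gives 6000 nM. For the measured compounds named here, the step from the first to the second is a 250-fold higher number from compound 1 to compound 2 (2.40 log units; beyond the scatter), which places compound 2 at the highest number of the two measured compounds, with compound 1 the only neighbour.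

Compound 3 `Cc1cccc2sc(NC(=O)CCN3CCN(c4ccncc4)CC3)nc12` carries the change (pyridin-4-yl in place of 1-methylpiperidin-4-yl on an amine nitrogen in a ring). Going by the values given here, no measured step covers this exact substitution; the only step that bears on it is the large rise seen in a 250-fold higher number from compound 1 to compound 2 (2.40 log units; beyond the scatter), which shows that the group on this ring nitrogen can move the number very strongly. Since compound 3 removes the 1-methylpiperidin-4-yl group that accompanied that rise and puts an aromatic ring in its place, the number for compound 3 is expected to fall relative to compound 2, by a step of a 12-fold lower number from compound 2 to compound 3 (1.08 log units; beyond the scatter), though without returning fully to the level of compound 1. The estimate for compound 3 is therefore 500 nM, within a range from 80 nM to 3000 nM.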

Compound 3, inhibition constant: 9600 nM
Beside the measured number, compound 3's estimate is 19-fold (1.28 log units) below it; measured number outside the range, above it.
By their numbers in this assay, from the lowest: compound 1; then compounds 2 and 3 (each within the scatter of the next).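

Read in this assay, the change from 1-methylpiperidin-4-yl to pyridin-4-yl is a 1.6-fold higher number from compound 2 to compound 3 (0.20 log units; within the scatter), so on this amine nitrogen in a ring the non-aromatic and the aromatic group cannot be told apart. Set against cyclohexyl, pyridin-4-yl gives a 400-fold higher number from compound 1 to compound 3 (2.60 log units; beyond the scatter), a large step like a 250-fold higher number from compound 1 to compound 2 (2.40 log units; beyond the scatter), so among these three compounds the two groups with a ring nitrogen both stand far from the cyclohexyl group of compound 1, whether or not their ring is aromatic. Nothing measured here speaks to the reason for this.

The compounds shown leave open whether the ring nitrogen itself goes with the large step, since a phenyl group on the same amine nitrogen, an aromatic ring with no ring nitrogen, could fall near compound 1 or near compounds 2 and 3, and a tetrahydropyran-4-yl group would put a ring oxygen where 1-methylpiperidin-4-yl has its nitrogen. They also leave open whether the same picture holds with a longer chain linking the amide carbonyl to the ring that bears these groups.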